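A few compounds are considered here, and "the series" means these few. Any claim that something is new, unique, unknown or untested is made for them only; others in the source may bear on it.

In a functional assay on HT-29 cells (Homo sapiens) for cytotoxicity, read by MTT assay, with a stated time of 24 h, tested at 16 ug/mL (a higher number here means a stronger effect of the compound at the concentration tested, a lower number a weaker effect), compound 2, `Cn1c(-c2ccc(NC(=O)CSC3=NCCS3)cc2)nc(-c2ccccc2)c1-c1ccccc1`, gives 43.3%, the lower of the two numbers recorded; compound 1, `Cn1cnnc1SCC(=O)Nc1ccc(-c2nc(-c3ccccc3)c(-c3ccccc3)n2C)cc1`, gives 59.1%. Compound 3, `Cn1ccnc1SCC(=O)Nc1ccc(-c2nc(-c3ccccc3)c(-c3ccccc3)n2C)cc1`, differs from compound 2 by a group of 6 heavy atoms (4 carbon, 2 nitrogen; one five-membered aromatic ring with 2 hetero atoms) in place of a group of 5 heavy atoms (3 carbon, 1 nitrogen, 1 sulfur; one five-membered non-aromatic ring with 2 hetero atoms), on a sulfur. Within the data shown here, the only measured step that bears on this change is a number 15.8 percentage points lower from compound 1 to compound 2 (beyond the scatter), where a five-membered aromatic ring left and a five-membered non-aromatic ring entered on the same sulfur; compound 3 brings an aromatic ring back. A modest rise is therefore expected, a number 11.7 percentage points higher from compound 2 to compound 3 (beyond the scatter), and compound 3 is estimated at 55%, with a range of 40% to 70%.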

Compound 3, a percentage reported as activity, at one concentration (the size of the read-out at that concentration, not a potency): 36.5%
The estimate for compound 3 lay 18.5 percentage points above the measured number; the measured number lies below the stated range.
By their numbers in this assay, from the lowest: compounds 3 and 2 (each within the scatter of the next); then compound 1.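

In this assay, an aromatic ring on the sulfur is not enough to match compound 1: 1-methyl-1H-imidazol-2-yl in place of 4-methyl-4H-1,2,4-triazol-3-yl gives a number 22.6 percentage points lower from compound 1 to compound 3 (beyond the scatter). The imidazole and the non-aromatic ring cannot be told apart, with a number 6.8 percentage points lower from compound 2 to compound 3 (within the scatter), so of these three groups only the triazole stands apart. Nothing available explains this difference. Open, as far as these compounds go, is where a tetrazole, a phenyl ring or a simple amine on the same sulfur would fall, and whether the triazole's separation from the other two groups would persist on a different core.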